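Side-chain amine variation across two cores

The source may hold more compounds than are shown below. What is called first, only, known or untested is meant among the compounds shown, and "the series" means these compounds.

Measured so far in a functional assay on A2780 cells (Homo sapiens) for antiproliferative activity, read by MTT assay, with a stated time of 48 h; a lower number here means a stronger inhibitor, a higher number a weaker inhibitor:
compound 1, `CCNCC(=O)Nc1cc(OC)ccc1C(=O)c1ccc(OC)c2c1OC(C)(C)C=C2`, 1980 nM
compound 2, `COc1ccc(C(=O)c2ccc(OC)c3c2OC(C)(C)C=C3)c(NC(=O)CN(C)C)c1`, 790 nM
compound 3, `CCNCC(=O)Nc1cc(OC)ccc1C(=O)c1cc(OC)c(OC)c(OC)c1`, 950 nM

Compound 1 and compound 2 share one core and differ only in the side chain: dimethylamino in place of ethylamino on a saturated chain carbon bound to a carbonyl carbon. This change gave a 2.5-fold lower number from compound 1 to compound 2 (0.40 log units; beyond the scatter) in this assay.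

Compound 3 carries a different core with the same ethylamino side chain as compound 1; the difference between the two cores is not broken down here. In this assay compound 3 gives 950 nM, a lower number than compound 1 shows, and a number that sits within the scatter of what compound 2 gives, so no order between compound 2 and compound 3 is claimed.

Compound 4, `COc1ccc(C(=O)c2cc(OC)c(OC)c(OC)c2)c(NC(=O)CN(C)C)c1`, is not yet measured. It stands to compound 3 as compound 2 stands to compound 1: dimethylamino in place of ethylamino on a saturated chain carbon bound to a carbonyl carbon. The place is the same in both pairs, so it is the same change, seen twice among the compounds shown. Going by the values given here, the only guide to its size is the single step from compound 1 to compound 2, on one core; whether the other core responds alike is not known from these three values. Taking the measured step as the best guide, compound 4 is expected to give 400 nM in this assay, between 200 nM and 900 nM, which means an estimated step of a 2.4-fold lower number from compound 3 to compound 4 (0.38 log units; beyond the scatter), resting on compound 3 at 950 nM and the earlier step of a 2.5-fold lower number from compound 1 to compound 2 (0.40 log units; beyond the scatter).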

Compound 4, half-maximal inhibitory concentration: 580 nM
Beside the measured number, compound 4's estimate is 1.5-fold (0.16 log units) below it; the measured number falls inside the stated range.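

Carried to the core of compound 3, dimethylamino in place of ethylamino gives a 1.6-fold lower number from compound 3 to compound 4 (0.21 log units; within the scatter) in this assay, so on this core the effect of the change alone cannot be told apart from repeat measurement. Set beside the step on the core of compound 1, the two steps cannot be separated: the same change on two cores in this assay, a 2.5-fold lower number (0.40 log units; beyond the scatter) from compound 1 to compound 2 and a 1.6-fold lower number (0.21 log units; within the scatter) from compound 3 to compound 4, 1.5-fold (0.18 log units) apart, within the scatter of two such steps This fits a change that carries from one core to the other, but it does not establish that, since only one of the two steps stands beyond the scatter and each core offers a single pair, so neither a shared size nor a size that depends on the core is shown.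

Still open, going by these compounds, is how the series reads with other amines on the saturated chain carbon bound to the carbonyl carbon, such as a primary amino group or diethylamino, or with a longer chain carrying the dimethylamino group. Also open, on these data alone, is whether the same change holds on any core other than these two.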